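Sulfonamide nitrogen substitution carried across two cores

A few compounds are considered here, and "the series" means these few. Any claim that something is new, unique, unknown or untested is made for them only; others in the source may bear on it.

Measured so far in a functional assay on MCF7 cells (Homo sapiens) for cytotoxicity, read by sulforhodamine B assay, with a stated time of 48 h; on this read-out higher numbers stand for weaker inhibition and lower numbers for stronger inhibition:
compound 1 `NS(=O)(=O)c1ccc(NC2=NS(=O)(=O)c3ccccc32)cc1`: 4.17 ug/mL
compound 2 `N=C(N)NS(=O)(=O)c1ccc(NC2=NS(=O)(=O)c3ccccc32)cc1`: 4.3 ug/mL
compound 3 `NS(=O)(=O)c1ccc(NNc2ncnc3ccccc23)cc1`: 1.13 ug/mL

Compound 2 differs from compound 1 by a group of 3 heavy atoms (1 carbon, 2 nitrogen; no ring) in place of a hydrogen atom, on a sulfonamide nitrogen and the step was a 1.0-fold higher number from compound 1 to compound 2 (0.01 log units; within the scatter). Compound 4 `N=C(N)NS(=O)(=O)c1ccc(NNc2ncnc3ccccc23)cc1` is the not yet measured partner of compound 3, differing by a group of 3 heavy atoms (1 carbon, 2 nitrogen; no ring) in place of a hydrogen atom, on a sulfonamide nitrogen. The place lines of the two changes read the same, so this is the same change on a second core. How the core of compound 3 differs from that of compound 1 is not broken down here; compound 3 simply stands at the lowest number of the three.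

For compound 4 the expected step is a 1.1-fold higher number from compound 3 to compound 4 (0.03 log units; within the scatter), because a 1.0-fold higher number from compound 1 to compound 2 (0.01 log units; within the scatter) showed the same change to leave the number essentially unmoved. Compound 4 is therefore estimated at 1.2 ug/mL, with a likely range from 0.5 ug/mL to 3 ug/mL in this assay.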

Compound 4, half-maximal inhibitory concentration: 1.65 ug/mL
Compound 4: middle estimate off by 1.4-fold (0.14 log units), on the low side; low and high end bracket the measured number.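

On the second core, the substitution on the sulfonamide nitrogen gives a 1.5-fold higher number from compound 3 to compound 4 (0.16 log units; within the scatter) in this assay and, as on the core of compound 1, the number stays within the scatter. The two steps agree: the same change on two cores in this assay, a 1.0-fold higher number (0.01 log units; within the scatter) from compound 1 to compound 2 and a 1.5-fold higher number (0.16 log units; within the scatter) from compound 3 to compound 4, 1.4-fold (0.15 log units) apart, within the scatter of two such steps

This shows the change carrying over from one core to the other with no readable effect on the number in this assay. It does not show that the same would hold on any further core or in other cells.

Still open, as far as these compounds go, is whether other groups on the sulfonamide nitrogen, such as a methyl or an acetyl group, would leave the number equally unmoved. Also open, from the compounds shown here alone, is whether a larger group, such as a phenyl ring, would do the same.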